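Swapping Isopropyl for Bromo on a Scaffold at the Limit

The compounds below may be only part of what the source reports. "The series", "measured", "known", "first", "only" and "open" are said of these compounds alone.

Compound 1, with the structure `CC(C)c1ccc(-c2nc(SCc3cn(CC(=O)NC(=O)Nc4ccccn4)nn3)nc(Nc3cccc(C(F)(F)F)c3)c2C#N)cc1`, was tested in a functional assay on MGC-803 cells (Homo sapiens) for inhibition, read by MTT assay, with a stated time of 72 h; on this read-out lower numbers stand for stronger inhibition and higher numbers for weaker inhibition. In this assay compound 1 gives only a limit of the assay, > 64000 nM, and no number. Compound 2, `CC(C)c1ccc(-c2nc(SCc3cn(CC(=O)NC(=O)Nc4ccccn4)nn3)nc(Nc3ccccc3F)c2C#N)cc1`, carries 2-fluorophenyl in place of 3-(trifluoromethyl)phenyl on a nitrogen on an aromatic ring. In this assay compound 2 likewise gives only a limit, > 64000 nM. The step that the two limits leave unreadable from compound 1 to compound 2 cannot be read because of the limit of > 64000 nM in this assay, at which 2 of the 2 values shown sit. Compound 3, `N#Cc1c(Nc2cccc(C(F)(F)F)c2)nc(SCc2cn(CC(=O)NC(=O)Nc3ccccn3)nn2)nc1-c1ccc(Br)cc1`, is not yet measured. It differs from compound 1 by bromo in place of isopropyl on an aromatic carbon of a six-membered aromatic ring of carbon only, para to a large group; cut one bond further out, 4-isopropylphenyl becomes 4-bromophenyl. Among the compounds with values here, no measured step touches this position, so the only guide is that both measured compounds sit at the limit. The step that the limit leaves unreadable from compound 1 to compound 3 is expected to stay within the scatter, with compound 3 most likely again reaching only the limit. Compound 3 is estimated at 100000 nM in this assay, within a range from 30000 nM to 300000 nM.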

Compound 3, half-maximal inhibitory concentration: 3600 nM
For compound 3 the middle estimate is 28-fold (1.44 log units) above the measured one; measured number outside the range, below it.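

At this position, on an aromatic carbon para to a large group, the group matters: in this assay, bromo in place of isopropyl brings an at least 17-fold lower number from compound 1 to compound 3 (1.24 log units; beyond the scatter). Within the data shown here, compound 3, at 3600 nM, is the only compound of the three that gives a real number. Among these compounds, compound 1 and compound 2 stay at one limit of the assay: the limit of > 64000 nM in this assay, at which 2 of the 3 values shown sit. The earlier change, on the aryl group carried by the nitrogen, could not be read, so this swap is the first change whose size can be stated, and even here one end of the comparison is a limit.

A single replacement cannot show whether bromine itself matters or whether simply losing isopropyl, with its 3 carbon atoms, is enough; chloro, methyl, methoxy or an amine at the same place would help to separate these readings. As far as these compounds go, it also stays open whether bromo would lift compound 2, with its 2-fluorophenyl group, off the limit in the same way, or whether the gain holds only alongside the 3-(trifluoromethyl)phenyl group of compound 3.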